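This account rests on a few compounds, and the source may have more. Where it says the series, first, only, none or still open, it means among the compounds named here.

Measured so far in a functional assay on A549 cells (Homo sapiens) for cytotoxicity, read by MTT assay, with a stated time of 48 h; a higher number here means a weaker inhibitor, a lower number a stronger inhibitor:

- compound 1 `COc1ccc(-c2nc3ccccn3c2C(=O)/C=C\Nc2cnc3ccccc3c2)cc1`: 1050 nM
- compound 2 `O=C(/C=C\Nc1ccc2[nH]ccc2c1)c1c(-c2ccc(Cl)cc2)nc2ccccn12`: 1010 nM
- compound 3 `O=C(/C=C\Nc1ccc2cc[nH]c2c1)c1c(-c2ccc(Cl)cc2)nc2ccccn12`: 2290 nM

In this assay, compound 3 carries the highest number of the three, and its gaps to the other two compounds both lie beyond the scatter. The next compound, compound 4 `O=C(/C=C\Nc1cnc2ccccc2c1)c1c(-c2ccc(Cl)cc2)nc2ccccn12`, keeps the core of compound 3 and changes only the group on the amine nitrogen, with quinolin-3-yl in place of 1H-indol-6-yl on an amine nitrogen.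

Within the data shown here, no measured pair shows this exchange directly. Among the measured compounds shown here, the one measured step at the same place is a 2.3-fold higher number from compound 2 to compound 3 (0.36 log units; beyond the scatter), which is modest but beyond the scatter. It shows that the number responds to a change in this group, though it involves only the two indolyl groups. Further guidance comes from compound 1, which bears the same quinolin-3-yl on the amine nitrogen but differs from compound 4 elsewhere. Compound 1 gives 1050 nM. A modest step toward a lower number in this assay is therefore expected, similar in size to the indolyl step. The estimate amounts to a 1.9-fold lower number from compound 3 to compound 4 (0.28 log units; within the scatter), an expected change that is only loosely constrained by so few data. Compound 4 is expected at about 1200 nM, with an estimated range from 550 nM to 2600 nM.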

Compound 4, half-maximal inhibitory concentration: 2880 nM
Estimate against measurement, compound 4: 2.4-fold (0.38 log units) below; the measured number lies above the stated range.
By their numbers in this assay, from the lowest: compounds 2 and 1 (each within the scatter of the next); then compounds 3 and 4 (each within the scatter of the next).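

In this assay, quinolin-3-yl and 1H-indol-6-yl on the amine nitrogen cannot be told apart (a 1.3-fold higher number from compound 3 to compound 4 (0.10 log units; within the scatter)), even though the two groups differ in ring size and in their counts of hydrogen-bond donors and acceptors. Set against 1H-indol-5-yl, however, quinolin-3-yl gives a step beyond the scatter (a 2.9-fold higher number from compound 2 to compound 4 (0.46 log units; beyond the scatter)), so among the three compounds carrying chloro, 1H-indol-5-yl alone stands apart at this position. Among these compounds, the result also supplies the first measured change at the other site, with chloro in place of methoxy on an aromatic carbon (a 2.7-fold higher number from compound 1 to compound 4 (0.44 log units; beyond the scatter)), which shows that quinolin-3-yl does not set the number on its own, as the opening estimate had assumed by leaning on compound 1.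

Nothing available explains why these groups differ in this way.

From the compounds shown here alone, it remains open whether the preference for 1H-indol-5-yl would persist with methoxy in place of chloro, and how a simple phenyl or a saturated ring such as piperidine would compare on the amine nitrogen, or fluoro at the aromatic carbon that now carries chloro.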